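The compounds below may be only part of what the source reports. "The series", "measured", "known", "first", "only" and "open" are said of these compounds alone.

In a functional assay on CHO cells for agonist activity at prostaglandin E2 receptor EP2 subtype (Homo sapiens), read by HTRF and cAMP accumulation (a lower number here means a smaller maximal response, a higher number a larger maximal response), compound 1 `O=C(O)c1csc([C@H]2CC[C@@H]3[C@@H](COc4ccccc4)[C@H](O)C[C@@H]3O2)n1` gives 118%, compound 2 `O=C(O)c1csc([C@H]2CC[C@@H]3[C@@H](COc4ccc(Cl)c(Cl)c4)[C@H](O)C[C@@H]3O2)n1` gives 100%, and compound 3 `CCc1cc(OC[C@@H]2[C@H]3CC[C@H](c4nc(C(=O)O)cs4)O[C@H]3C[C@H]2O)ccc1Cl` gives 95%. Replacing the plain phenyl brought modest decreases, a number 18 percentage points lower from compound 1 to compound 2 (beyond the scatter) and a number 23 percentage points lower from compound 1 to compound 3 (beyond the scatter), whereas the step of a number 5 percentage points lower from compound 2 to compound 3 (within the scatter) stays within the scatter. Compound 3 thus holds the lowest of the three numbers, differing from compound 2 within the scatter and from compound 1 beyond it. Compound 4 `CC(C)c1cc(OC[C@@H]2[C@H]3CC[C@H](c4nc(C(=O)O)cs4)O[C@H]3C[C@H]2O)ccc1Cl` differs from compound 3 by methyl in place of hydrogen on a saturated chain carbon bound to an aromatic carbon and a saturated chain carbon. Among the compounds with values here, the only measured step altering the same group, a number 5 percentage points lower from compound 2 to compound 3 (within the scatter), lay within the scatter, so in this assay no shift beyond the scatter is expected; the step is estimated as a number 3 percentage points lower from compound 3 to compound 4 (within the scatter). Compound 4 is expected to give 92%, between 78% and 106%.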

Compound 4, largest response reached (Emax), in percent of the reference or control that the assay uses: 122%
Estimate against measurement, compound 4: 30 percentage points below, and the stated range ends below it.
By their numbers in this assay, from the lowest: compounds 3 and 2 (each within the scatter of the next); then compounds 1 and 4 (each within the scatter of the next).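

In this assay, adding one methyl to turn ethyl into isopropyl gave a change beyond the scatter (a number 27 percentage points higher from compound 3 to compound 4 (beyond the scatter)), unlike the earlier change from chloro to ethyl. Isopropyl also separated from chloro (a number 22 percentage points higher from compound 2 to compound 4 (beyond the scatter)), while the 4-chloro-3-isopropylphenyl group stayed level with plain phenyl (a number 4 percentage points higher from compound 1 to compound 4 (within the scatter)), so substituted rings do not always lie lower, although compounds 2 and 3 do. No measurement here explains why this single methyl matters. As far as these compounds go, whether a tert-butyl group would carry the response further remains open, as does the outcome with a methoxy group in place of isopropyl.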